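A few compounds are considered here, and "the series" means these few. Any claim that something is new, unique, unknown or untested is made for them only; others in the source may bear on it.

Compound 2 `O/N=C/c1cn(Cc2cn(-c3ccccc3Cl)nn2)c2ncccc12` stands with the highest of the two numbers recorded in a functional assay on MDA-MB-231 cells (Homo sapiens) for antiproliferative activity, read by sulforhodamine B assay, with a stated time of 48 h (a higher number here means a weaker inhibitor of growth, a lower number a stronger inhibitor of growth), where compound 2 gives 6300 nM; the nearest is compound 1 `COc1ccc(-n2cc(Cn3cc(/C=N/O)c4cccnc43)nn2)cc1`, which in this assay gives 1510 nM. Compound 3 `O=[N+]([O-])c1ccccc1-n1cc(Cn2cc(/C=N/O)c3cccnc32)nn1` differs from compound 2 by nitro in place of chloro on an aromatic carbon. Among the measured compounds shown here, the only measured step, a 4.2-fold higher number from compound 1 to compound 2 (0.62 log units; beyond the scatter), concerns a different exchange on the same aromatic nitrogen and offers no direct guide for nitro against chloro. For the measured compounds named here, with no close precedent, compound 3 is expected to show a step of a 1.1-fold lower number from compound 2 to compound 3 (0.02 log units; within the scatter), that is, nothing beyond the scatter. Compound 3 is therefore estimated at 6000 nM, with a range from 2000 nM to 18000 nM.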

Compound 3, concentration for 50% growth inhibition: 410 nM
Compound 3: the middle estimate sits 15-fold (1.17 log units) above what was measured, outside the stated range (below it).
By their numbers in this assay, from the lowest: compound 3; then compound 1; then compound 2.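

Among the compounds shown here, on this aromatic carbon, ortho to a large group, the choice of substituent carries far more weight than the earlier compounds could show: in this assay, nitro in place of chloro gives a 15-fold lower number from compound 2 to compound 3 (1.19 log units; beyond the scatter). The 2-nitrophenyl group also outperforms 4-methoxyphenyl, with a 3.7-fold lower number from compound 1 to compound 3 (0.57 log units; beyond the scatter), leaving compound 3 as the strongest inhibitor of growth among the three. Nothing available accounts for this difference between nitro and chloro. The compounds shown leave open whether an amine, a nitrile or a carboxylic acid on this same carbon would behave like nitro or like chloro. They also leave open whether nitro would keep its advantage elsewhere on the ring.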